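This account rests on a few compounds, and the source may have more. Where it says the series, first, only, none or still open, it means among the compounds named here.

In a functional assay on the whole organism with Rattus norvegicus as the target (a higher number here means that more compound is needed for the effect, a lower number that less compound is needed), the measured compounds stand as follows:

Compound 1 `CCOCCOC(=O)C(=O)Nc1nc(-c2cc(OC)no2)cs1` gives 3 mg/kg.
Compound 2 `CCOCCOC(=O)C(=O)Nc1nc(-c2cc(C)no2)cs1` gives 0.04 mg/kg.
Compound 3 `COc1cc(-c2csc(NC(=O)C(=O)O)n2)on1` gives 1.2 mg/kg.

Compound 4 `Cc1cc(-c2csc(NC(=O)C(=O)O)n2)on1` has not yet been measured in this assay. It differs from compound 3 by methyl in place of methoxy on an aromatic carbon. The same change has already been made once among these compounds, from compound 1 to compound 2, described as methyl in place of methoxy on an aromatic carbon, and there it produced a 75-fold lower number from compound 1 to compound 2 (1.88 log units; beyond the scatter). The two cores on which the change is made are not identical: compound 3 differs from compound 1 by hydrogen in place of 2-ethoxyethyl on an oxygen next to a carbonyl group, a change that on its own gave a 2.5-fold lower number from compound 1 to compound 3 (0.40 log units; beyond the scatter). The place of the change is described in the same words for both pairs, so what is being asked is whether methyl in place of methoxy on an aromatic carbon carries its large effect over from the core of compound 1 to the core of compound 3.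

For the measured compounds named here, only one instance of the change has been seen, so its size on the second core is not guaranteed. Going by the values given here, a large step is nevertheless expected from compound 3 to compound 4, on the order of a 40-fold lower number from compound 3 to compound 4 (1.60 log units; beyond the scatter), because the single precedent gave a 75-fold lower number from compound 1 to compound 2 (1.88 log units; beyond the scatter) and the core difference of a 2.5-fold lower number from compound 1 to compound 3 (0.40 log units; beyond the scatter) is modest by comparison. Compound 4 is therefore estimated to give 0.03 mg/kg in this assay, with the expectation placed between 0.008 mg/kg and 0.15 mg/kg.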

Compound 4, dose for half-maximal effect: 0.3 mg/kg
Compound 4: middle estimate off by 10-fold (1.00 log units), on the low side, outside the stated range (above it).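

In this assay, methyl in place of methoxy on an aromatic carbon again gives a lower number on the second core, a 4.0-fold lower number from compound 3 to compound 4 (0.60 log units; beyond the scatter), so the direction of the change carries over from the core of compound 1 to the core of compound 3, but its size does not: the same change on two cores in this assay, a 75-fold lower number (1.88 log units; beyond the scatter) from compound 1 to compound 2 and a 4.0-fold lower number (0.60 log units; beyond the scatter) from compound 3 to compound 4, 19-fold (1.27 log units) apart, beyond the scatter of two such steps

Seen from the other side of the same four compounds, hydrogen in place of 2-ethoxyethyl on an oxygen next to a carbonyl group gives a 7.5-fold higher number from compound 2 to compound 4 (0.88 log units; beyond the scatter), whereas it gave a lower number in the methoxy pair, so the two changes do not simply add: the same change on two cores in this assay, a 2.5-fold lower number (0.40 log units; beyond the scatter) from compound 1 to compound 3 and a 7.5-fold higher number (0.88 log units; beyond the scatter) from compound 2 to compound 4, 19-fold (1.27 log units) apart, beyond the scatter of two such steps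

This shows that, among these four compounds, the step for either change depends on the group present at the other place, but it does not show why, and with only two cores it gives no rule for how large the step would be on any further core.

The compounds shown leave open how an ethyl group, a chlorine or an amine would compare with methyl and methoxy on that aromatic carbon. They also leave open whether a shorter chain such as ethyl on the oxygen next to the carbonyl group would keep the large step seen with 2-ethoxyethyl.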